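Changing the sulfonamide group of compound 3

The source may hold more compounds than are shown below. What is called first, only, known or untested is meant among the compounds shown, and "the series" means these compounds.

In a functional assay on cells (leukaemia cell line, Homo sapiens) for inhibition, read by sulforhodamine B assay, with a stated time of 48 h (a higher number here means a weaker inhibitor of growth, a lower number a stronger inhibitor of growth), three compounds have been measured so far:
- compound 1 `O=S(=O)(Nc1ccc(F)c(Cl)c1)c1ccc(-c2cnc(C3CC3)o2)cc1` gives 260 nM
- compound 2 `O=S(=O)(Nc1cccc(Cl)c1)c1ccc(-c2cnc(C3CC3)o2)cc1` gives 477 nM
- compound 3 `Cc1ccc(NS(=O)(=O)c2ccc(-c3cnc(C4CC4)o3)cc2)cc1C` gives 420 nM

Compound 3 stands within the scatter of both other compounds, and compound 2 is its nearest neighbour. Compound 4 `Cc1ccc(Cl)c(NS(=O)(=O)c2ccc(-c3cnc(C4CC4)o3)cc2)c1` has 2-chloro-5-methylphenyl in place of 3,4-dimethylphenyl on a sulfonamide nitrogen and keeps the shared core. Two measured swaps of this same group bear on it: a 1.6-fold higher number from compound 1 to compound 3 (0.21 log units; within the scatter) and a 1.1-fold lower number from compound 2 to compound 3 (0.06 log units; within the scatter) while hydrogen in place of fluoro gave a 1.8-fold higher number from compound 1 to compound 2 (0.26 log units; within the scatter) as well. For the measured compounds named here, none of the measured compounds carries a 2-chloro-5-methylphenyl group, so the expectation remains uncertain. In this assay no step beyond the scatter is expected, in either direction. The estimate means a 1.1-fold higher number from compound 3 to compound 4 (0.06 log units; within the scatter) as the expected step. For compound 4 the estimated value is 480 nM with an expected range from 200 nM to 1100 nM in this measurement.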

Compound 4, concentration for 50% growth inhibition: 48.8 nM
Compound 4: middle estimate off by 9.8-fold (0.99 log units), on the high side, outside the stated range (below it).
By their numbers in this assay, from the lowest: compound 4; then compounds 1, 3 and 2 (each within the scatter of the next).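

In this assay the group on the sulfonamide nitrogen can move the number well beyond the scatter, which the earlier swaps there did not show: 2-chloro-5-methylphenyl gives a clear drop in each comparison (an 8.6-fold lower number from compound 3 to compound 4 (0.93 log units; beyond the scatter)) (a 9.8-fold lower number from compound 2 to compound 4 (0.99 log units; beyond the scatter)) (a 5.3-fold lower number from compound 1 to compound 4 (0.73 log units; beyond the scatter)). Compound 4 is therefore the strongest inhibitor of growth of the four. Nothing measured here explains this change.

The compounds shown do not separate the part played by the chloro from that of the methyl in the new group. On these data alone, how an amine or a carboxylic acid on that phenyl ring would read also stays open.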